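A few compounds are considered here, and "the series" means these few. Any claim that something is new, unique, unknown or untested is made for them only; others in the source may bear on it.

Series notes on half-life. Compound 1 `CCn1c(-c2ccc(C(F)(F)F)nc2)nc2c(O[C@H]3CCN(C(=O)c4cocn4)C3)ncnc21` stands highest of the two numbers in hand for an ADME assay (Rattus norvegicus, strain Wistar Han) for metabolic stability (a higher number here means that the compound lasts longer, a lower number that the compound disappears faster), giving 6 h. Compound 2 `CCn1c(-c2cnc(C)nc2)nc2c(O[C@H]3CCN(C(=O)C4CC(F)(F)C4)C3)ncnc21` differs from compound 1 in several places. In this assay, going by the values given here, compound 2 gives 1.4 h; the gap between the two lies beyond the scatter, but no single-change step connects them, so the two values only show that the series spans a range. Compound 3 `CCn1c(-c2ccc(C(F)(F)F)nc2)nc2c(O[C@H]3CCN(C(=O)C4CC4)C3)ncnc21` has not yet been measured in this assay. Against compound 1 it carries one change: cyclopropyl in place of 1,3-oxazol-4-yl on a carbonyl carbon. Among the compounds with values here, no step between measured compounds covers this change, so its direction rests on expectation alone. In this assay a modest loss, somewhat beyond the scatter, is expected. The step from compound 1 to compound 3 is estimated as a 1.7-fold lower number from compound 1 to compound 3 (0.23 log units; within the scatter). For compound 3 the expected half-life is 3.5 h, with a range from 1.5 h to 9 h.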

Compound 3, half-life: 0.7 h
Compound 3: the middle estimate sits 5.0-fold (0.70 log units) above what was measured; measured number outside the range, below it.
By their numbers in this assay, from the lowest: compounds 3 and 2 (each within the scatter of the next); then compound 1.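

In this assay, the place on a carbonyl carbon bonded to an amide-type nitrogen in a ring now has its first single-change reading: cyclopropyl in place of 1,3-oxazol-4-yl gives an 8.6-fold lower number from compound 1 to compound 3 (0.93 log units; beyond the scatter) with the rest of compound 1 unchanged. The two earlier compounds differed in several places and showed only a spread, whereas this one place alone moves the half-life beyond the scatter. No measurement in hand accounts for this step.

With a single step, the aromatic ring, its hetero atoms and the ring size all change together and cannot be separated. On these data alone, a phenyl, a cyclopentyl or a tert-butyl group on the same carbonyl would help to separate them, and whether the step carries over to other groups elsewhere on the core remains open.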